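Losing the phenol hydroxyl on the way to a phenethyl side chain

A few compounds are considered here, and "the series" means these few. Any claim that something is new, unique, unknown or untested is made for them only; others in the source may bear on it.

Compound 1 `CN1CCC[C@@H]1Cn1nc(Cc2ccc(O)cc2)c2ccccc2c1=O` stands with the higher of the two numbers measured in an assay for binding affinity to Alpha-1B adrenergic receptor (Homo sapiens); a higher number here means a weaker inhibitor, a lower number a stronger inhibitor: compound 1 gives 398 nM, while compound 2 `CN1CCCCC(n2nc(Cc3ccc(Cl)cc3)c3ccccc3c2=O)C1` gives 158 nM, a gap beyond the scatter. Compound 3 `CN1CCC[C@@H]1Cn1nc(CCc2ccccc2)c2ccccc2c1=O` differs from compound 1 by benzyl in place of 4-hydroxyphenyl on a saturated chain carbon bound to an aromatic carbon, so the hydrogen-bond donor and acceptor of the hydroxyl are gone. For the measured compounds named here, with no single-point step between measured compounds to lean on, only a small change in this assay is expected, toward a slightly lower number. Compound 3 is therefore estimated at 300 nM, within 100 nM to 900 nM, a step of a 1.3-fold lower number from compound 1 to compound 3 (0.12 log units; within the scatter).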

Compound 3, inhibition constant: 200 nM
The estimate for compound 3 lay 1.5-fold (0.18 log units) above the measured number, and the stated range covers the measured number.
By their numbers in this assay, from the lowest: compounds 2, 3 and 1 (each within the scatter of the next, the first and the last beyond it).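

Across the swap of 4-hydroxybenzyl for phenethyl, this assay gives a 2.0-fold lower number from compound 1 to compound 3 (0.30 log units; within the scatter). For the compounds shown here, this is the first step read at this position, and it shows that the side chain can lose the hydroxyl, with its hydrogen-bond donor and acceptor, without a change that stands clear of the scatter. No measurement offers an explanation for this step.
Compound 3 both lacks the hydroxyl and carries the longer chain, so the compounds shown do not separate these two differences. A plain benzyl or a 4-hydroxyphenethyl side chain on the same core would separate them.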